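The source may hold more compounds than are shown below. What is called first, only, known or untested is meant among the compounds shown, and "the series" means these compounds.

Working notes on the series.

Two compounds of this set carry a measured number. Compound 1 `COc1ccc2cc(C(C)c3nnc4n3N=C(c3ccc(C)cc3)CS4)ccc2c1` in a functional assay on HCT-116 cells (Homo sapiens) for inhibition, read by sulforhodamine B assay, with a stated time of 72 h (a lower number here means a stronger inhibitor, a higher number a weaker inhibitor), gives 10200 nM. Compound 2 `CC(C)Cc1ccc(C(C)c2nnc3n2N=C(c2ccc(OC(F)(F)F)cc2)CS3)cc1` in this assay gives 3000 nM, the lower of the two numbers, and compound 1 stands a clear way above it, beyond the usual scatter. Compound 3 `CC(C)Cc1ccc(C(C)c2nnc3n2N=C(c2ccc(Cl)cc2)CS3)cc1` has not been measured in this assay. It differs from compound 2 in one place: chloro in place of trifluoromethoxy on an aromatic carbon. Among the measured compounds shown here, no measured pair in the set shows the effect of such an exchange, so there is nothing here to fix its direction. The step from compound 2 to compound 3 is expected to be small, within the scatter or only just beyond it, with no firm direction, a 1.2-fold higher number from compound 2 to compound 3 (0.07 log units; within the scatter). On that basis compound 3 is expected to give about 3500 nM in this assay, within a range from 1200 nM to 10000 nM.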

Compound 3, half-maximal inhibitory concentration: 6700 nM
Compound 3: middle estimate off by 1.9-fold (0.28 log units), on the low side; the measured number falls inside the stated range.
By their numbers in this assay, from the lowest: compound 2; then compounds 3 and 1 (each within the scatter of the next).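

Among the compounds shown here, the first measured exchange on this aromatic carbon of a six-membered aromatic ring of carbon only, para to a large group, shows that the group here matters in this assay: chloro in place of trifluoromethoxy gives a modest step (a 2.2-fold higher number from compound 2 to compound 3 (0.35 log units; beyond the scatter)). For this one pair the direction is now fixed, with trifluoromethoxy, 5 heavy atoms against 1 for chloro, giving the lower number and so the stronger inhibitor of the two. No measurement bears on the cause of this step.

Going by these compounds, whether an amine, a carboxylic acid or a longer chain at this place would give a lower or a higher number than compound 2 remains open. Also open, on these data alone, is whether the exchange keeps this size when the rest of compound 2 changes.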